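A Side-Chain Swap Weighed Against a Short Half-Life

The compounds below may be only part of what the source reports. "The series", "measured", "known", "first", "only" and "open" are said of these compounds alone.

Three compounds sharing one core have been run in an ADME assay on microsomes from liver (Rattus norvegicus) for metabolic stability; on this read-out lower numbers stand for a shorter-lived compound and higher numbers for a longer-lived compound. Compound 1, `CC(C)[C@H](C[C@H]1CCNC1=O)c1ccc(-c2ccc3cccc(F)c3c2)[nH]c1=O`, gives 0.227 h. Compound 2, `CCn1ncc2c(F)cc(-c3ccc(C(CC)(CC)c4nncn4C)c(=O)[nH]3)cc21`, gives > 3 h, and this is a limit of the assay rather than a number. Compound 3, `CC(C)C(Nc1nccs1)c1ccc(-c2ccc3cccc(F)c3c2)[nH]c1=O`, gives 0.07 h, the lowest of the two plain numbers; compound 1 stands higher by a gap beyond the usual scatter. Among the measured compounds shown here, only one of the three values sits at the limit of > 3 h in this assay, at which 1 of the 3 values shown sits.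

The untested compound 4, `CC(C)NC(=O)CC(c1ccc(-c2ccc3cccc(F)c3c2)[nH]c1=O)C(C)C`, differs from compound 3 in one place: (isopropylcarbamoyl)methyl in place of (1,3-thiazol-2-yl)amino on a saturated chain carbon bound to an aromatic carbon and a saturated chain carbon. For the measured compounds named here, no pair of measured compounds differs in exactly one place, so the size of this step has no measured precedent. The side chain entering compound 4 carries an amide, and compound 1, which also holds an amide in its side chain, gives 0.227 h in this assay, well above compound 3. On that basis the change is expected to raise the half-life, with a 2.9-fold higher number from compound 3 to compound 4 (0.46 log units; beyond the scatter) expected to reach beyond the scatter. Compound 4 is estimated at 0.2 h, with a plausible range from 0.07 h to 0.6 h.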

Compound 4, half-life: < 0.0667 h
Compound 4: no number, only a limit; the forecaster's own chance of this, stated with the estimate: 3%; at least 2.9-fold (0.47 log units) between middle value and limit.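

The first swap measured at this position, on a saturated chain carbon bound to an aromatic carbon and a saturated chain carbon, brings no longer half-life in this assay. Compound 4 gives < 0.0667 h, which is a limit of the assay and not a number. That limit leaves an at least 1.0-fold lower number from compound 3 to compound 4 (0.02 log units; that floor lies within the scatter), so compound 4 cannot be separated from compound 3 on these data, yet the ringless (isopropylcarbamoyl)methyl clearly does not lift the compound out of the short-lived end of the read-out, where the ring-bearing (1,3-thiazol-2-yl)amino already sat, and it marks the bottom of what is reported here: the limit of < 0.0667 h in this assay, at which 1 of the 4 values shown sits.

Going by these compounds, whether a plain amine, a carboxylic acid or a longer chain on that same carbon would give a longer half-life on this core stays open. Also open is how much of the long half-life of compound 2 belongs to its side chain and how much to the rest of the molecule, as it differs from the others in more than one place and its value is only a limit: the limit of > 3 h in this assay, at which 1 of the 4 values shown sits.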